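Swapping an aromatic ring for a saturated ring

The source may report more compounds than this note shows. Statements on the series, on what has been measured and on what is new or still open speak of the compounds shown alone.

Compound 1 `Nc1cccc(CNc2cc(C(F)(F)F)cc3[nH]ncc23)c1`: 68%
Compound 2 `O=C(O)c1cccc(CNc2cc(C(F)(F)F)cc3[nH]ncc23)c1`: 81%

Both numbers come from an assay for inhibition of Tryptophan 2,3-dioxygenase (Homo sapiens), with stated times of 10 min and 60 min, tested at 10 uM; a lower number here means a weaker effect, a higher number a stronger effect of the compound at the concentration tested. Among the measured compounds shown here, compound 1 stands lowest of the two measured compounds, and compound 2 stands a number 13 percentage points higher from compound 1 to compound 2 (beyond the scatter), the only measured step, produced by setting carboxy in place of amino on an aromatic carbon.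

Compound 3 `FC(F)(F)c1cc(NC[C@@H]2CCCCN2)c2cn[nH]c2c1` is not yet measured. It differs from compound 1 by piperidin-2-yl in place of 3-aminophenyl on a saturated chain carbon bound to a nitrogen on an aromatic ring. For the measured compounds named here, no measured step bears directly on this change: the one step known alters a group on an aromatic carbon, whereas here the six-membered aromatic ring of carbon only gives way to a six-membered non-aromatic ring with one hetero atom, so it offers no guide to direction. Without such a guide, the expectation for compound 3 in this assay is an estimated step of a number 8 percentage points lower from compound 1 to compound 3 (within the scatter) that need not exceed the usual scatter, with wide uncertainty. The estimate for compound 3 is 60%, within 35% to 80%.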

Compound 3, a percentage reported as inhibition, at one concentration (the size of the read-out at that concentration, not a potency): 64%
Beside the measured number, compound 3's estimate is 4 percentage points below it, and the stated range covers the measured number.
By their numbers in this assay, from the lowest: compounds 3 and 1 (each within the scatter of the next); then compound 2.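

At the saturated chain carbon bound to a nitrogen on an aromatic ring, piperidin-2-yl in place of 3-aminophenyl gives, in this assay, a number 4 percentage points lower from compound 1 to compound 3 (within the scatter). The position therefore tolerates a six-membered non-aromatic ring with one hetero atom as well as a six-membered aromatic ring of carbon only, so for this pair an aromatic ring here is not needed to keep the read-out at this single concentration. Nothing available gives a reason for this result.

On these data alone, it remains open whether a carboxylic acid on the saturated ring would bring a step like a number 13 percentage points higher from compound 1 to compound 2 (beyond the scatter), which was seen on the aromatic ring. The compounds shown also do not tell how the opposite stereocentre of piperidin-2-yl, a morpholine ring or a longer chain carrying the piperidine would behave.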